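Dropping the Sulfonyl Bridge for a Naphthyl Ring

The source may report more compounds than this note shows. Statements on the series, on what has been measured and on what is new or still open speak of the compounds shown alone.

Compound 1 `Cc1c(Cc2ccccc2S(=O)(=O)c2cccc(Cl)c2)c2c(n1CC(=O)O)CCNC2=O`: 4 nM
Compound 2 `COc1ccc(S(=O)(=O)c2ccccc2Cc2c3c(n(CC(=O)O)c2C)CCNC3=O)cc1`: 3.9 nM

In a functional assay on CHO.K1 cells for antagonist activity at prostaglandin D2 receptor 2 (Homo sapiens), read by GTPgammaS binding, with a stated time of 1 h (on this read-out higher numbers stand for weaker inhibition and lower numbers for stronger inhibition), compound 2 gives 3.9 nM, the lower of the two numbers shown, although compound 1 sits within the scatter of it. Going by the values given here, the only measured step, a 1.0-fold lower number from compound 1 to compound 2 (0.01 log units; within the scatter), swapped one aryl group on the sulfonyl sulfur for another and stayed within the scatter. Compound 3 `Cc1c(Cc2ccccc2-c2cccc3ccccc23)c2c(n1CC(=O)O)CCNC2=O` differs by naphthalen-1-yl in place of (4-methoxyphenyl)sulfonyl on an aromatic carbon. Among the compounds with values here, no measured step bears on this, since the sulfonyl link itself disappears rather than only its aryl group. The expected step is a 7.7-fold higher number from compound 2 to compound 3 (0.89 log units; beyond the scatter), toward weaker inhibition, with wide uncertainty. Compound 3 is therefore estimated at 30 nM, with a range from 4 nM to 300 nM.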

Compound 3, half-maximal inhibitory concentration: 480 nM
Compound 3: middle estimate off by 16-fold (1.20 log units), on the low side; measured number outside the range, above it.
By their numbers in this assay, from the lowest: compounds 2 and 1 (each within the scatter of the next); then compound 3.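

Changing the aryl group on the sulfonyl sulfur stayed within the scatter, but replacing the whole group with naphthalen-1-yl gives a 120-fold higher number from compound 2 to compound 3 (2.09 log units; beyond the scatter) in this assay on this aromatic carbon. The other sulfonyl compound shows much the same loss, with a 120-fold higher number from compound 1 to compound 3 (2.08 log units; beyond the scatter) as the step. So the aryl group on the sulfur could change freely in these compounds, yet this swap costs much inhibition, and no measurement here explains why.

Losing the sulfonyl link and gaining the naphthalen-1-yl ring happen in one step, so their separate shares stay open. A plain phenyl ring on the same aromatic carbon, or naphthalen-1-yl carried on a sulfonyl link, would help separate them.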